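Two aryl substitution patterns on a thioether and a sulfone

The compounds below may be only part of what the source reports. "The series", "measured", "known", "first", "only" and "open" are said of these compounds alone.

Compound 1 `CC(O)(CSc1cccc(OC(F)(F)F)c1)C(=O)Nc1cc(C(F)(F)F)cc(C(F)(F)F)c1` gives 7760 nM in a functional assay on LNCaP cells (Homo sapiens) for antiproliferative activity, read by fluorescence and propidium iodide staining, with a stated time of 96 h; on this read-out lower numbers stand for stronger inhibition and higher numbers for weaker inhibition.
Compound 2 `CC(O)(CSc1ccccc1OC(F)(F)F)C(=O)Nc1cc(C(F)(F)F)cc(C(F)(F)F)c1` gives 2910 nM in this assay.
Compound 3 `CC(O)(CS(=O)(=O)c1cccc(OC(F)(F)F)c1)C(=O)Nc1cc(C(F)(F)F)cc(C(F)(F)F)c1` gives 9340 nM in this assay.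

Between compound 1 and compound 2 the only difference is 2-(trifluoromethoxy)phenyl in place of 3-(trifluoromethoxy)phenyl on a sulfur, and it brought a 2.7-fold lower number from compound 1 to compound 2 (0.43 log units; beyond the scatter). The cores of compound 1 and compound 3 differ in a way that is not broken down here; the two values are within the scatter of each other. Compound 4 `CC(O)(CS(=O)(=O)c1ccccc1OC(F)(F)F)C(=O)Nc1cc(C(F)(F)F)cc(C(F)(F)F)c1` is not yet measured. It differs from compound 3 by 2-(trifluoromethoxy)phenyl in place of 3-(trifluoromethoxy)phenyl on a sulfonyl sulfur, the same kind of change as from compound 1 to compound 2, though the place is not the same: on a sulfur in one case, on a sulfonyl sulfur in the other. Resting on the step from compound 1 to compound 2 a 2.7-fold lower number from compound 1 to compound 2 (0.43 log units; beyond the scatter), a step of a 2.7-fold lower number from compound 3 to compound 4 (0.43 log units; beyond the scatter) is expected for compound 4, with added uncertainty as the place differs. Compound 4 is expected to give about 3500 nM, between 1400 nM and 9000 nM, in this assay.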

Compound 4, half-maximal inhibitory concentration: 8020 nM
Compound 4: middle estimate off by 2.3-fold (0.36 log units), on the low side, within the range that was stated.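

On a sulfonyl sulfur, in this assay, putting 2-(trifluoromethoxy)phenyl in place of 3-(trifluoromethoxy)phenyl gave a 1.2-fold lower number from compound 3 to compound 4 (0.07 log units; within the scatter). Set beside the step on the core of compound 1, the two steps cannot be told apart: the same change on two cores in this assay, a 2.7-fold lower number (0.43 log units; beyond the scatter) from compound 1 to compound 2 and a 1.2-fold lower number (0.07 log units; within the scatter) from compound 3 to compound 4, 2.3-fold (0.36 log units) apart, within the scatter of two such steps

So the data do not show that the core alters the effect of this change, but neither do they show that the lower number seen on the first core carries over, since the step on the second core is no larger than the scatter. The compounds shown leave open what a sulfoxide would do at the sulfur. They also leave open how a methoxy group or a chlorine would compare with trifluoromethoxy on the phenyl ring.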